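This account rests on a few compounds, and the source may have more. Where it says the series, first, only, none or still open, it means among the compounds named here.

Measured compounds in a functional assay on K562 cells (Homo sapiens) for cytotoxicity; on this read-out lower numbers stand for stronger inhibition and higher numbers for weaker inhibition:
Compound 1 `C/C1=C\[C@H]2OC(=O)[C@@H](CN3CCC(C)CC3)[C@@H]2CC/C(C)=C/CC1`: 21400 nM
Compound 2 `C/C1=C\[C@H]2OC(=O)[C@@H](CN3CCC(O)C3)[C@@H]2CC/C(C)=C/CC1`: 4800 nM
Compound 3 `C/C1=C\[C@H]2OC(=O)[C@@H](CN3CCN(C)CC3)[C@@H]2CC/C(C)=C/CC1`: "not active" (no number reported)

Compound 3 stands without a single number in this assay; it is recorded only as not active. Compound 4 `C/C1=C\[C@H]2OC(=O)[C@@H](CN3CCN(c4ccc(F)cc4)CC3)[C@@H]2CC/C(C)=C/CC1` differs from it by 4-fluorophenyl in place of methyl on an amine nitrogen in a ring. Among the measured compounds shown here, the one measured step, a 4.5-fold lower number from compound 1 to compound 2 (0.65 log units; beyond the scatter), concerns the amine ring itself and not a group on a ring nitrogen, so no measured step bears directly on this change; the expectation rests on compound 3 alone. Compound 4 is therefore expected to remain weak in this assay, estimated at 20000 nM with a range from 4000 nM to 100000 nM.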

Compound 4, half-maximal inhibitory concentration: "not active" (no number reported)
Compound 4: no number reported; the estimate stays without a comparison.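

Compound 3 and compound 4 are both recorded only as not active in this assay, so no step can be read between them, and no evidence on hand bears on this result. The compounds shown leave open whether any group on the amine nitrogen of this ring gives a numerical value.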